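The source may report more compounds than this note shows. Statements on the series, on what has been measured and on what is new or still open speak of the compounds shown alone.

Compound 1 `COc1ccc(NC(=O)NCCCOc2cccc(CN3CCCCC3)c2)c(OC)c1`: 2240 nM
Compound 2 `Cc1ccc(NC(=O)NCCCOc2cccc(CN3CCCCC3)c2)cc1`: 631 nM

Among the compounds with values here, in an assay on isolated protein for inhibition of histamine H2 receptor (Cavia porcellus) (on this read-out lower numbers stand for tighter binding and higher numbers for weaker binding), compound 2 gives 631 nM, the lower of the two numbers measured so far, while compound 1 gives 2240 nM. Within the data shown here, the one measured step, a 3.5-fold lower number from compound 1 to compound 2 (0.55 log units; beyond the scatter), came from putting 4-methylphenyl in place of 2,4-dimethoxyphenyl on the amide-type nitrogen, a modest move.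

Compound 3 `CNC(=O)NCCCOc1cccc(CN2CCCCC2)c1` differs from compound 2 in one place: methyl in place of 4-methylphenyl on an amide-type nitrogen. Among the measured compounds shown here, the measured step bears on this only loosely: it shows that exchanging substituents on the ring that sits on this amide-type nitrogen shifts the number by a modest amount, but no measured compound lacks the ring altogether, so how much the ring itself contributes is not known from these two numbers. Removing it is a larger change than the one measured, and a weakening of roughly the same size as that step, in the opposite direction, is what is expected here, that is a step of a 3.2-fold higher number from compound 2 to compound 3 (0.50 log units; beyond the scatter). Compound 3 is therefore estimated at 2000 nM, with a range from 600 nM to 7000 nM.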

Compound 3, dissociation constant: 155 nM
Estimate against measurement, compound 3: 13-fold (1.11 log units) above; the measured number lies below the stated range.
By their numbers in this assay, from the lowest: compound 3; then compound 2; then compound 1.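

In this assay, the ring on the amide-type nitrogen turns out not to be required for the tightest binding seen among these compounds: methyl in place of 4-methylphenyl brings a 4.1-fold lower number from compound 2 to compound 3 (0.61 log units; beyond the scatter) and methyl in place of 2,4-dimethoxyphenyl brings a 14-fold lower number from compound 1 to compound 3 (1.16 log units; beyond the scatter) in the same direction. The earlier pair showed only that changing the substituents on that ring moves the number, whereas these steps show that losing the ring altogether, with only a methyl left in its place, gives the lowest number of the three, and both steps lie beyond the scatter. Nothing available explains why this exchange lowers the number.

The three compounds cannot separate the loss of the aromatic ring from the loss of size, a question that cyclohexyl on this nitrogen would bear on directly. They also leave open whether the trend continues to a bare hydrogen on this nitrogen, or whether ethyl, a longer chain or benzyl would keep the number as low as methyl does.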